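A few compounds are considered here, and "the series" means these few. Any claim that something is new, unique, unknown or untested is made for them only; others in the source may bear on it.

Among the measured compounds shown here, compound 2 `COc1cc(Cl)cc(-c2nn(-c3cccc(NC(=O)Nc4ccc(Cl)c(Cl)c4)c3)cc2-c2ccncc2)c1` holds the lower of the two numbers so far in a functional assay on SW-620 cells (Homo sapiens) for inhibition, read by sulforhodamine B assay, with a stated time of 48 h, tested at 10 uM (on this read-out higher numbers stand for a weaker effect at the one concentration tested and lower numbers for a stronger effect), where compound 2 gives 13.3%; compound 1 `COc1cc(Cl)cc(-c2nn(-c3cccc(NC(=O)c4ccc(Cl)c(Cl)c4)c3)cc2-c2ccncc2)c1` gives 84.2%, and the only counted step, a number 70.9 percentage points lower from compound 1 to compound 2 (beyond the scatter), separates them. Compound 3 `COc1cc(Cl)cc(-c2nn(-c3cccc(NC(=O)c4cccc(C(F)(F)F)c4)c3)cc2-c2ccncc2)c1` differs from compound 2 by 3-(trifluoromethyl)phenyl in place of (3,4-dichlorophenyl)amino on a carbonyl carbon. For the measured compounds named here, that step partly reverses the one measured change: the amide-type nitrogen and its attached ring leave the carbonyl carbon, while the ring that enters carries a trifluoromethyl group rather than two chlorines, a substitution with no counterpart among the measured pair. Given the size of a number 70.9 percentage points lower from compound 1 to compound 2 (beyond the scatter), a large step back towards weaker activity is expected, a number 61.7 percentage points higher from compound 2 to compound 3 (beyond the scatter), with compound 3 estimated at 75%, between 45% and 95%.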

Compound 3, a percentage reported as activity, at one concentration (the size of the read-out at that concentration, not a potency): 77%
Estimate against measurement, compound 3: 2 percentage points below; low and high end bracket the measured number.
By their numbers in this assay, from the lowest: compound 2; then compounds 3 and 1 (each within the scatter of the next).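

In this assay, 3-(trifluoromethyl)phenyl in place of (3,4-dichlorophenyl)amino on the carbonyl carbon gives a number 63.7 percentage points higher from compound 2 to compound 3 (beyond the scatter) and so the strong effect of compound 2 is not kept with this second ring once the amino nitrogen is gone. With no amino nitrogen on either side, the change of ring gives a number 7.2 percentage points lower from compound 1 to compound 3 (within the scatter) and so 3-(trifluoromethyl)phenyl and 3,4-dichlorophenyl cannot be told apart at this position. Open, on these data alone, is whether (3-(trifluoromethyl)phenyl)amino on the carbonyl carbon matches compound 2, and whether an oxygen linker or a methylene in place of the amino nitrogen does. No evidence bears on the cause of these steps.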